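A few compounds are considered here, and "the series" means these few. Any claim that something is new, unique, unknown or untested is made for them only; others in the source may bear on it.

Measured so far:
- compound 1, `COc1ccc(N2CCn3nc(COc4ccccc4)cc3C2=O)cc1`: 58%
- compound 2, `O=C1c2cc(COc3cccc(F)c3)nn2CCN1c1ccc(F)cc1`: 70%

Both numbers come from a functional assay on HEK293 cells for positive allosteric modulation of metabotropic glutamate receptor 5 (Homo sapiens), read by calcium flux; a higher number here means a larger maximal response, a lower number a smaller maximal response. On the numbers shown, compound 2 stands highest of the two; its nearest neighbour is compound 1, which sits lower by more than the usual scatter. The two compounds differ in more than one place, so no single change can be credited with that gap.

The step under consideration leads from compound 2 to compound 3, `O=C1c2cc(COc3cccnc3)nn2CCN1c1ccc(F)cc1`, which has not yet been measured. The change is pyridin-3-yl in place of 3-fluorophenyl on an oxygen on a saturated carbon. Among the compounds with values here, with no comparable step among the measured compounds, the size of the change is open; a modest fall in this assay is expected, roughly at the edge of the scatter, and the step from compound 2 to compound 3 is estimated at a number 10 percentage points lower from compound 2 to compound 3 (within the scatter). Compound 3 is therefore expected to give about 60%, somewhere between 40% and 80%.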

Compound 3, largest response reached (Emax), in percent of the reference or control that the assay uses: 69%
Beside the measured number, compound 3's estimate is 9 percentage points below it; measured number inside the range.
By their numbers in this assay, from the lowest: compound 1; then compounds 3 and 2 (each within the scatter of the next).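

Putting pyridin-3-yl in place of 3-fluorophenyl on this oxygen in this assay gives a number 1 percentage points lower from compound 2 to compound 3 (within the scatter). Within the data shown here, this is the first single-place comparison, and it shows that the aromatic ring at this position can carry a ring nitrogen, counted as a hydrogen-bond acceptor, in place of the fluorine-bearing carbon ring with no change in maximal response beyond the scatter. No available evidence explains why the two rings give such similar responses.

This single pair cannot show how far that tolerance extends, for example to a pyridin-4-yl ring, a saturated cyclohexyl ring, or an aromatic ring bearing an amine or a carboxylic acid. It also leaves open whether the same swap would give a similar result with a different group on the core's other ring.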